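The source may report more compounds than this note shows. Statements on the series, on what has been measured and on what is new or still open speak of the compounds shown alone.

Four compounds share one core, a sugar joined to a fused two-ring aromatic system, and differ at only two places on it. Compound 2 `C#Cc1cn([C@@H]2O[C@H](CO)[C@@H](O)[C@H]2O)c2ncnc(C)c12` carries an ethynyl group on the five-membered ring and a methyl group on the six-membered ring. Compound 1 `Cc1ncnc2c1c(I)cn2[C@@H]1O[C@H](CO)[C@@H](O)[C@H]1O` keeps the methyl but has iodine in place of the ethynyl; that change is iodo in place of ethynyl on an aromatic carbon. Compound 3 `C#Cc1cn([C@@H]2O[C@H](CO)[C@@H](O)[C@H]2O)c2ncnc(OC)c12` keeps the ethynyl but has a methoxy group where the methyl was, and the difference between the two cores is methoxy in place of methyl on an aromatic carbon. Compound 4 `COc1ncnc2c1c(I)cn2[C@@H]1O[C@H](CO)[C@@H](O)[C@H]1O` combines the methoxy core with the iodo group, so its difference from compound 3 is iodo in place of ethynyl on an aromatic carbon, the same change that separates compound 2 from compound 1.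

In a functional assay on HepG2 cells (Homo sapiens) for antiproliferative activity, read by XTT assay, with a stated time of 72 h (a higher number here means a weaker inhibitor, a lower number a stronger inhibitor), compound 2 gives 290 nM. In this assay compound 1 gives 3460 nM, a step of a 12-fold higher number from compound 2 to compound 1 (1.08 log units; beyond the scatter). In this assay compound 3 gives 12700 nM, a step of a 44-fold higher number from compound 2 to compound 3 (1.64 log units; beyond the scatter), and it has the highest number of the three measured compounds.

If the iodo-for-ethynyl change acts on the methoxy core as it did on the methyl core, compound 4 is expected to show a step of about a 7.9-fold higher number from compound 3 to compound 4 (0.90 log units; beyond the scatter), resting on a 12-fold higher number from compound 2 to compound 1 (1.08 log units; beyond the scatter). Compound 4 is therefore expected to give roughly 100000 nM in this assay, with a likely range from 30000 nM to 400000 nM. Among the measured compounds shown here, because compound 3 already gives 12700 nM, such a number would place compound 4 well beyond every compound measured so far, and an expected value this high carries considerable uncertainty.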

Compound 4, half-maximal inhibitory concentration: > 20000 nM
Compound 4 was reported as a limit; the forecaster's own chance of this, stated with the estimate: 40%; the middle value lies beyond the limit too.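

In this assay compound 4 gives > 20000 nM, which is a limit of the assay and not a number. Putting iodo in place of ethynyl on the methoxy core gives an at least 1.5-fold higher number from compound 3 to compound 4 (0.19 log units; that floor lies within the scatter), so this result alone does not establish a change beyond the scatter, and it cannot show whether the change carries over at full size from the methyl core: the same change on two cores in this assay, a 12-fold higher number (1.08 log units; beyond the scatter) from compound 2 to compound 1 and an at least 1.5-fold higher number (0.19 log units; that floor lies within the scatter) from compound 3 to compound 4; the limit leaves it open whether they differ Putting methoxy in place of methyl on the iodo-bearing core gives an at least 5.7-fold higher number from compound 1 to compound 4 (0.76 log units; beyond the scatter), so this change raises the number on both cores beyond the scatter, which shows that its direction carries over in this pair of cores, but not that its size does: the same change on two cores in this assay, a 44-fold higher number (1.64 log units; beyond the scatter) from compound 2 to compound 3 and an at least 5.7-fold higher number (0.76 log units; beyond the scatter) from compound 1 to compound 4; the limit leaves it open whether they differ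

As far as these compounds go, how far the true value of compound 4 lies past its limit stays open, and with it whether either change depends on the core it is made on. Also open, from the compounds shown here alone, is how other groups would behave in this assay, such as a nitrile or an amine in place of ethynyl on the five-membered aromatic ring, or a longer chain in place of methyl or methoxy on the shared core.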